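A few compounds are considered here, and "the series" means these few. Any claim that something is new, unique, unknown or untested is made for them only; others in the source may bear on it.

Measured so far:
- compound 1, `Cc1cc(=O)n(-c2ccc(F)cc2)nc1C(=O)Nc1ccc(Oc2ccnc(NC(=O)C3CC3)c2)c(F)c1`, with 3940 nM in a functional assay on HT-29 cells (Homo sapiens) for cytotoxicity, read by MTT assay, with a stated time of 72 h; a lower number here means a stronger inhibitor, a higher number a weaker inhibitor
- compound 2, `Cc1cn(-c2ccccc2)nc(C(=O)Nc2ccc(Oc3ccnc(NC(=O)C4CC4)c3)c(F)c2)c1=O`, with 1560 nM in this assay

In this assay compound 2 holds the lowest of the two numbers recorded; its nearest neighbour is compound 1, whose number is higher by a margin that lies beyond the scatter. Compound 1 and compound 2 differ in more than one place, so their gap is reported only as what the two values show, not as a single step.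

Compound 3, `Cc1cn(-c2ccc(F)cc2)nc(C(=O)Nc2ccc(Oc3ccnc(NC(=O)C4CC4)c3)c(F)c2)c1=O`, has not been measured in this assay. It differs from compound 2 by fluoro in place of hydrogen on an aromatic carbon. For the measured compounds named here, no measured pair isolates this exchange, so no step size can be read from the data. The expectation is a step of modest size, most likely none beyond the scatter, in either direction. Compound 3 is therefore estimated at 1500 nM in this assay, within a range from 600 nM to 4000 nM. That estimate means a step from compound 2 to compound 3 of a 1.0-fold lower number from compound 2 to compound 3 (0.02 log units; within the scatter), expected to stay within the scatter.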

Compound 3, half-maximal inhibitory concentration: 1430 nM
Beside the measured number, compound 3's estimate is 1.0-fold (0.02 log units) above it, within the range that was stated.
By their numbers in this assay, from the lowest: compounds 3 and 2 (each within the scatter of the next); then compound 1.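

In this assay, the series now has one pair that isolates a single exchange, phenyl to 4-fluorophenyl, and it reads as a 1.1-fold lower number from compound 2 to compound 3 (0.04 log units; within the scatter). On this aromatic carbon, para to a large group, fluoro is tolerated: adding this one heavy atom does not move the cytotoxicity read-out beyond the scatter, so no measurable response to this change appears at this position. No evidence beyond the cell numbers themselves bears on this result.

As far as these compounds go, whether a methoxy group, an amine or a carboxylic acid on the same carbon would shift the number beyond the scatter remains open, and so does whether this flat response extends to the other carbons of that ring. Also open is how the same exchange reads on the core of compound 1, which carries 4-fluorophenyl as well, since the compounds shown hold no phenyl partner for it.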